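This account rests on a few compounds, and the source may have more. Where it says the series, first, only, none or still open, it means among the compounds named here.

Compound 1 `COc1cc2c(Oc3ccc(NC(=O)NN4C(=O)CSC4c4c(F)cccc4F)c(Cl)c3)ccnc2cc1OCCCN1CCCC1`: in a functional assay on A549 cells (Homo sapiens) for antiproliferative activity, read by MTT assay, with a stated time of 72 h (on this read-out lower numbers stand for stronger inhibition and higher numbers for weaker inhibition), compound 1 gives 960 nM.
Compound 2 `CCN1CCN(CCCOc2cc3nccc(Oc4c(F)cc(NC(=O)NN5C(=O)CSC5c5c(F)cccc5F)cc4F)c3cc2OC)CC1`: in this assay compound 2 gives 350 nM.

Of these two, compound 2 has the lowest number, and the step from it to compound 1 lies beyond the scatter. Compound 3 `COc1cc2c(Oc3c(F)cc(NC(=O)NN4C(=O)CSC4c4c(F)cccc4F)cc3F)ccnc2cc1OCCCN1C[C@H]2CCCC[C@H]2C1` differs from compound 2 in one place: a group of 9 heavy atoms (8 carbon, 1 nitrogen; one five-membered non-aromatic ring with 1 hetero atom, one six-membered non-aromatic ring of carbon only) in place of a group of 8 heavy atoms (6 carbon, 2 nitrogen; one six-membered non-aromatic ring with 2 hetero atoms), on a saturated chain carbon, three bonds along the chain from an oxygen on an aromatic ring. For the measured compounds named here, no measured pair isolates this exchange, so its effect is unknown; the expectation is a small change, with no step beyond the scatter in either direction in this assay. Compound 3 is estimated at 450 nM, between 150 nM and 1300 nM, which is expected to mean a step of a 1.3-fold higher number from compound 2 to compound 3 (0.11 log units; within the scatter).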

Compound 3, half-maximal inhibitory concentration: 1930 nM
The estimate for compound 3 lay 4.3-fold (0.63 log units) below the measured number; measured number outside the range, above it.
By their numbers in this assay, from the lowest: compound 2; then compounds 1 and 3 (each within the scatter of the next).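

In this assay the group at the end of this chain clearly matters: the exchange brings a 5.5-fold higher number from compound 2 to compound 3 (0.74 log units; beyond the scatter) and so weaker inhibition. The entering group has one nitrogen rather than two and one hydrogen-bond acceptor rather than two, but it also differs in its rings, and this single pair cannot separate these changes. Nothing available explains the loss. On these data alone, whether a morpholine on the same chain would keep the inhibition of compound 2 stays open, as does the role of the two defined stereocentres in compound 3.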